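The source may report more compounds than this note shows. Statements on the series, on what has been measured and on what is new or still open speak of the compounds shown alone.

Measured so far in a functional assay on A2780 cells (Homo sapiens) for antiproliferative activity, read by CellTiter-Glo, with a stated time of 72 h; a higher number here means a weaker inhibitor, a lower number a stronger inhibitor:
- compound 1 `C[C@H](NC(=O)[C@@H]1CCCN1C)c1ccc(NC(=O)N2CC(c3ccc(N)nc3)C2)cc1` gives 11 nM
- compound 2 `C[C@H](NC(=O)C1CCOCC1)c1ccc(NC(=O)N2CC(c3cncc(N)c3)C2)cc1` gives 500 nM

Compound 2 has the higher number of the two, and its gap to compound 1 lies beyond the scatter. Compound 3 `C[C@H](NC(=O)[C@@H]1CCCN1C)c1ccc(NC(=O)N2CC(c3cncc(N)c3)C2)cc1` follows from compound 2 by one change 1-methylpyrrolidin-2-yl in place of oxan-4-yl on a carbonyl carbon on a carbonyl carbon. Among the compounds with values here, no measured step isolates this change. Compound 1, which also carries 1-methylpyrrolidin-2-yl, gives 11 nM and so a lower number beyond the scatter is expected in this assay for this change. The estimated size is a 14-fold lower number from compound 2 to compound 3 (1.15 log units; beyond the scatter) in this direction. Compound 3 is expected at 35 nM within an estimated range of 8 nM to 160 nM in this series.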

Compound 3, half-maximal inhibitory concentration: 34 nM
Beside the measured number, compound 3's estimate is 1.0-fold (0.01 log units) above it, and the stated range covers the measured number.
By their numbers in this assay, from the lowest: compound 1; then compound 3; then compound 2.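

In this assay, the change to 1-methylpyrrolidin-2-yl in place of oxan-4-yl on a carbonyl carbon is now isolated, giving a 15-fold lower number from compound 2 to compound 3 (1.17 log units; beyond the scatter) with the rest of the structure fixed. The aminopyridine group also has its first isolated reading, with 5-aminopyridin-3-yl in place of 6-aminopyridin-3-yl on a saturated ring carbon giving a 3.1-fold higher number from compound 1 to compound 3 (0.49 log units; beyond the scatter) in this series. Nothing available explains either step.

As far as these compounds go, it remains open whether the oxan-4-yl change gives a similar step with 6-aminopyridin-3-yl present. From the compounds shown here alone, the effect of an open-chain amine or a carboxylic acid on that carbonyl carbon also remains open.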